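Transferring a Chloro Substitution to a Second Core

The source may report more compounds than this note shows. Statements on the series, on what has been measured and on what is new or still open speak of the compounds shown alone.

Compound 1 `CS(=O)(=O)NCCN1CCC(CNC(=O)c2cccc3[nH]cnc23)CC1` and compound 2 `CS(=O)(=O)NCCN1CCC(CNC(=O)c2cc(Cl)cc3[nH]cnc23)CC1` share one core. In an assay on membranes from striatum with 5-hydroxytryptamine receptor 4 (Rattus norvegicus) as the target (on this read-out higher numbers stand for weaker inhibition and lower numbers for stronger inhibition), compound 1 gives 11.5 nM, and compound 2 gives 0.11 nM. The change between them, (chloro in place of hydrogen on an aromatic carbon), brought a 100-fold lower number from compound 1 to compound 2 (2.02 log units; beyond the scatter). Compound 3 `CS(=O)(=O)NCCN1CCC(COC(=O)c2cccc3[nH]cnc23)CC1` is built on a different core; the difference between the two cores is not broken down here. In this assay compound 3 gives 26.3 nM, the highest of the three measured numbers. Compound 4 `CS(=O)(=O)NCCN1CCC(COC(=O)c2cc(Cl)cc3[nH]cnc23)CC1` has not yet been measured; it differs from compound 3 by chloro in place of hydrogen on an aromatic carbon, the same change at the same place as from compound 1 to compound 2. Resting on a 100-fold lower number from compound 1 to compound 2 (2.02 log units; beyond the scatter), compound 4 is expected to show a 66-fold lower number from compound 3 to compound 4 (1.82 log units; beyond the scatter), a step of similar size, with some caution since the core differs. Compound 4 is thus estimated at 0.4 nM in this assay, between 0.1 nM and 1.5 nM.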

Compound 4, inhibition constant: 2.29 nM
Estimate against measurement, compound 4: 5.7-fold (0.76 log units) below, outside the stated range (above it).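

In this assay the chloro change works in the same direction on the second core, giving an 11-fold lower number from compound 3 to compound 4 (1.06 log units; beyond the scatter). For the compounds shown here, the size of the step does not carry over, however, and the two cores give clearly different gains: the same change on two cores in this assay, a 100-fold lower number (2.02 log units; beyond the scatter) from compound 1 to compound 2 and an 11-fold lower number (1.06 log units; beyond the scatter) from compound 3 to compound 4, 9.1-fold (0.96 log units) apart, beyond the scatter of two such steps With only two pairs, this shows that the direction held here, but it does not explain the difference in size or predict the step on any further core.

The compounds shown leave open whether bromo, fluoro or methyl on the same aromatic carbon would also give a step that differs between the two cores. They also leave open how the chloro step would behave with a longer chain on the ring nitrogen.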